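Swapping chloro for cyano on the amide aryl ring

A few compounds are considered here, and "the series" means these few. Any claim that something is new, unique, unknown or untested is made for them only; others in the source may bear on it.

Of the compounds shown here, two sharing one core have been measured in a functional assay (Sus scrofa) with sulfonylurea receptors; K-ATP channels (Homo sapiens) as the target; on this read-out higher numbers stand for an effect only at larger amounts of compound and lower numbers for an effect already at smaller amounts. Compound 1 `CC(=O)Nc1c(C(O)(C(F)(F)F)C(F)(F)F)ccc2ccccc12` gives 95.5 nM. Within the data shown here, compound 2 `O=C(Nc1c(C(O)(C(F)(F)F)C(F)(F)F)ccc2ccccc12)c1cccc(Cl)c1` gives 851 nM, the higher of the two numbers; the only measured step, an 8.9-fold higher number from compound 1 to compound 2 (0.95 log units; beyond the scatter), separates it from compound 1. Compound 3 `N#Cc1cccc(C(=O)Nc2c(C(O)(C(F)(F)F)C(F)(F)F)ccc3ccccc23)c1` differs from compound 2 by cyano in place of chloro on an aromatic carbon. Among the measured compounds shown here, no measured step covers this exchange: the single known step concerns the group on the carbonyl carbon, not a substituent on the aryl ring, so it gives no guide to the direction or size of this change. On that basis the expected step from compound 2 to compound 3 is a 1.0-fold lower number from compound 2 to compound 3 (0.00 log units; within the scatter), a change not expected to go beyond the scatter. In this assay compound 3 is therefore estimated at 850 nM, with a range from 300 nM to 2500 nM.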

Compound 3, half-maximal effective concentration: 372 nM
Compound 3: middle estimate off by 2.3-fold (0.36 log units), on the high side; the range from low to high includes it.
By their numbers in this assay, from the lowest: compound 1; then compound 3; then compound 2.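

Until this point only the group on the carbonyl carbon had changed, and this exchange shows that in this assay a substituent on the aromatic ring also moves the result, with a 2.3-fold lower number from compound 2 to compound 3 (0.36 log units; beyond the scatter) as 3-cyanophenyl replaces 3-chlorophenyl. The aryl amide still does not match the small methyl amide, with a 3.9-fold higher number from compound 1 to compound 3 (0.59 log units; beyond the scatter) as the remaining gap, so the nitrile wins back only part of the rise seen with 3-chlorophenyl. Nothing available explains why the cyano group gives the lower number.

Still open, on these data alone, is how other groups would behave at this place on the ring, such as an amine, a methoxy group or a carboxylic acid. Also open, as far as these compounds go, is whether any substituted phenyl amide can reach the number of compound 1 95.5 nM on this core.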